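The source may hold more compounds than are shown below. What is called first, only, known or untested is meant among the compounds shown, and "the series" means these compounds.

Measured in a functional assay on A549 cells (Homo sapiens) for inhibition, read by sulforhodamine B assay, with a stated time of 48 h, tested at 10 uM; a lower number here means less inhibition of growth, a higher number more inhibition of growth at the concentration tested:
Compound 1 `CC(=O)c1ccc(NC(=O)Cn2nc(-c3ccc(Cl)cc3)nc2N)cc1`: 22%
Compound 2 `COc1ccc(-c2nc3sc(-c4ccccc4)cn3n2)cc1`: 49%
Compound 3 `C/C(=N/O)c1ccc(NC(=O)Cn2nc(C(F)(F)F)nc2N)cc1`: 29%

Of these three compounds, compound 2 stands highest in this assay, at 49%. Compound 3 lies lower, and compound 1 lower still, and both gaps to compound 2 are beyond the scatter. Compounds 1 and 3 share an amide chain that compound 2 lacks, and they differ from it in too many places to show what any single group contributes.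

The next compound, compound 4 `c1ccc(-c2nc3sc(-c4ccccc4)cn3n2)cc1`, keeps the core of compound 2 and changes one substituent: hydrogen in place of methoxy on an aromatic carbon. Going by the values given here, no measured pair in this small set isolates a change of this kind, so the size of the step has no direct precedent. The starting point is the value of compound 2, 49%, and a single small substituent change on an otherwise unchanged structure is expected to shift it only modestly. The most likely outcome is therefore no step beyond the scatter, with a slight lean towards less inhibition. The expected change is a number 7 percentage points lower from compound 2 to compound 4 (within the scatter). For compound 4 the estimated value is 42%, with an expected range from 25% to 58%.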

Compound 4, percent growth inhibition at one concentration: 10%
Estimate against measurement, compound 4: 32 percentage points above; the whole stated range lies above it.
By their numbers in this assay, from the lowest: compound 4; then compounds 1 and 3 (each within the scatter of the next); then compound 2.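

In this assay, going by these compounds alone, hydrogen in place of methoxy gives a number 39 percentage points lower from compound 2 to compound 4 (beyond the scatter), the first step in this set that can be read at a single place, and it is a large one. It shows that the group on this aromatic carbon, para to a large group, is not a minor detail in this series: with the rest of the structure unchanged, exchanging the methoxy, with its 2 heavy atoms, for a hydrogen atom takes compound 4 down to 10%. The information given here offers nothing that explains why the step is this large.

The compounds shown do not tell whether a hydroxyl, an ethoxy group, a chlorine atom or an amine on this same carbon would stand nearer to compound 2 or to compound 4, so it remains unclear whether the higher number depends on methoxy specifically or on having any group there other than hydrogen. They also leave open whether a methoxy placed elsewhere on the core of compound 2 would give a similar number, since this single step speaks for one position only.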